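The source may report more compounds than this note shows. Statements on the series, on what has been measured and on what is new or still open speak of the compounds shown alone.

Compound 1 `COc1ccc(CNCc2c(OC)cc(Oc3cccc(Nc4ccccc4)c3)cc2OC)cc1` gives 2650 nM in a functional assay on HCT-15 cells (Homo sapiens) for inhibition, read by MTT assay, with a stated time of 72 h; on this read-out lower numbers stand for stronger inhibition and higher numbers for weaker inhibition. Among the measured compounds shown here, its only measured neighbour, compound 2 `COc1cc(Oc2cccc(Nc3ccccc3)c2)cc(OC)c1CNCc1ccccc1`, gives 5020 nM in this assay; the step of a 1.9-fold higher number from compound 1 to compound 2 (0.28 log units; within the scatter) concerns a methoxy group on an aromatic carbon and therefore does not touch the amine-bearing chain. Compound 3 `COc1ccc(CCCNCc2c(OC)cc(Oc3cccc(Nc4ccccc4)c3)cc2OC)cc1` differs from compound 1 by 2-(4-methoxyphenyl)ethyl in place of 4-methoxyphenyl on a saturated chain carbon bound to an amine nitrogen. For the measured compounds named here, no measured step bears on a longer chain here, so no step beyond the scatter is expected, in either direction. Compound 3 is therefore estimated at 2700 nM, with a range of 1000 nM to 7500 nM, an expected step of a 1.0-fold higher number from compound 1 to compound 3 (0.01 log units; within the scatter).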

Compound 3, half-maximal inhibitory concentration: 730 nM
For compound 3 the middle estimate is 3.7-fold (0.57 log units) above the measured one, outside the stated range (below it).
By their numbers in this assay, from the lowest: compound 3; then compounds 1 and 2 (each within the scatter of the next).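

Lengthening the chain on the amine nitrogen, from 4-methoxybenzyl to 3-(4-methoxyphenyl)propyl, moves the result beyond the scatter in this assay (a 3.6-fold lower number from compound 1 to compound 3 (0.56 log units; beyond the scatter)), which the methoxy step between the two earlier compounds did not do. The comparison with the phenyl-bearing compound points the same way (a 6.9-fold lower number from compound 2 to compound 3 (0.84 log units; beyond the scatter)), so this position clearly affects inhibition of these cells. Nothing available explains why the longer chain gives stronger inhibition. Still open, from the compounds shown here alone, is whether a longer chain, such as 4-(4-methoxyphenyl)butyl, would strengthen inhibition further. Also open, going by these compounds, is whether the 3-phenylpropyl group, lacking the methoxy, would perform like compound 3.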